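This account rests on a few compounds, and the source may have more. Where it says the series, first, only, none or still open, it means among the compounds named here.

Measured so far:
compound 1 `COC(c1cc(Cl)c2c(c1Cl)C(=O)N(Cc1c(C)cc(C)[nH]c1=O)CC2)C1CCS(=O)(=O)CC1` — 15 uL/min; 40 uL/min (2 entries)
compound 2 `Cc1cc(C)c(CN2CCc3c(Cl)cc([C@H](C)CO)c(Cl)c3C2=O)c(=O)[nH]1` — 15.8 uL/min

Among the compounds with values here, in an ADME assay on microsomes from liver (Homo sapiens) for metabolic stability, read by LC-MS, using NADPH, with stated times of 10 min and 45 min, tested at 1 uM (on this read-out lower numbers stand for slow clearance and higher numbers for fast clearance), compound 2 gives 15.8 uL/min; this is the only number for it, and a further entry carries no single number. Compound 1 gives 15 uL/min; 40 uL/min (2 entries), and the several entries of compound 1 in this assay, 15 uL/min; 40 uL/min (2 entries) shows how far repeats of one compound can sit apart. Compound 3 `Cc1cc(C)c(CN2CCc3c(Cl)cc([C@@H](C)CO)c(Cl)c3C2=O)c(=O)[nH]1` differs from compound 2 only as follows: the two compounds have the same atoms and bonds and differ only in configuration as drawn: 1 of 1 stereo elements differ; a stereocentre at a saturated chain carbon is drawn S in compound 2 and R in compound 3. Within the data shown here, no step between measured compounds is available here. A change of configuration alone is expected to give a step of a 1.0-fold higher number from compound 2 to compound 3 (0.01 log units; within the scatter), which is none beyond the scatter. Compound 3 is estimated at 16 uL/min, within a range from 8 uL/min to 32 uL/min.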

Compound 3, intrinsic clearance in a liver preparation (reported as CLH), per the amount of preparation that the assay uses: 12.4 uL/min
Compound 3: the middle estimate sits 1.3-fold (0.11 log units) above what was measured; the measured number falls inside the stated range.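

In this assay, the change of configuration at the saturated chain carbon gives a 1.3-fold lower number from compound 2 to compound 3 (0.11 log units; within the scatter), so the two drawn configurations at this stereocentre are not told apart by this read-out. Within the data shown here, this pair is the first comparison that isolates configuration at this position. The step is small beside the spread between repeats of one compound: the several entries of compound 1 in this assay, 15 uL/min; 40 uL/min (2 entries)

Going by these compounds, whether configuration at this stereocentre stays equally silent with an amine or a carboxylic acid on this chain, or with a longer chain, remains open. The pair speaks only for the hydroxyl-bearing chain on the shared core.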